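Removing the methoxy from compound 1: working notes

This account rests on a few compounds, and the source may have more. Where it says the series, first, only, none or still open, it means among the compounds named here.

Measured in a functional assay on Jurkat cells (Homo sapiens) for cytotoxicity, read by MTT assay, with a stated time of 72 h; a lower number here means a stronger inhibitor, a higher number a weaker inhibitor:
- compound 1 `COC(=O)c1sc2cc(OC)ccc2c1Nc1cc(OC)c(OC)c(OC)c1` gives 1.7 nM
- compound 2 `COC(=O)c1sc2nc(C)ccc2c1Nc1cc(OC)c(OC)c(OC)c1` gives 0.6 nM

Of these two numbers, compound 1 has the higher, and the gap down to compound 2 lies beyond the scatter. The two compounds differ in more than one place, so their gap does not isolate any single change.

Compound 3 `COC(=O)c1sc2ccccc2c1Nc1cc(OC)c(OC)c(OC)c1` is compound 1 with hydrogen in place of methoxy on an aromatic carbon. Within the data shown here, no measured pair shows this change on its own, so its size has to be judged without a direct precedent. Both measured compounds carry a substituent in that part of the core, with compound 1 at 1.7 nM and compound 2 at 0.6 nM. Compound 3 has none there, and a weaker result is therefore expected, with a step well beyond the scatter. The expected change is an 18-fold higher number from compound 1 to compound 3 (1.25 log units; beyond the scatter). For compound 3 the estimated value is 30 nM, with an expected range from 4 nM to 250 nM.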

Compound 3, half-maximal inhibitory concentration: 490 nM
The estimate for compound 3 lay 16-fold (1.21 log units) below the measured number, and the stated range ends below it.
By their numbers in this assay, from the lowest: compound 2; then compound 1; then compound 3.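

In this assay, among these compounds, hydrogen in place of methoxy on an aromatic carbon is the first change that can be read on its own, and it gives a 290-fold higher number from compound 1 to compound 3 (2.46 log units; beyond the scatter) for the loss of only 2 heavy atoms. The methoxy at this place, meta to a fused ring and para to a fused ring, is therefore far from a neutral decoration on the core of compound 1: in this assay, much of the potency of compound 1 depends on having it there rather than hydrogen. No measurement shown here bears on the reason for a step of this size.

The compounds shown leave open whether this demand is specific to methoxy or whether another group at the same place, such as ethoxy, hydroxyl, fluorine or an amine, would restore the number of compound 1. Among the compounds shown here, they also leave open whether the same change would have a similar size on a different core, as this one step is the only reading of it so far.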